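The source may hold more compounds than are shown below. What is called first, only, known or untested is meant among the compounds shown, and "the series" means these compounds.

In a functional assay (aorta) with Rattus norvegicus as the target (a lower number here means that less compound is needed, a higher number that more compound is needed for the effect), compound 1 (`COc1ccc(-c2nc(N=C(N)N)sc2-c2ccc(OC)cc2)cc1`) gives 2 uM, compound 2 (`COc1ccc(-c2nc(CN(C)C)sc2-c2ccc(OC)cc2)cc1`) gives 8.4 uM and compound 3 (`COc1ccc(-c2nc(CNC(=O)C3=NNC(=O)CC3)sc2-c2ccc(OC)cc2)cc1`) gives 7.3 uM. Compound 3 thus stands within the scatter of compound 2, and the values of both are higher than that of compound 1. Compound 4 (`COc1ccc(-c2nc(CNC(=O)N3CCOCC3)sc2-c2ccc(OC)cc2)cc1`) has not yet been measured. It differs from compound 3 as follows: a group of 6 heavy atoms (4 carbon, 1 nitrogen, 1 oxygen; one six-membered non-aromatic ring with 2 hetero atoms) in place of a group of 7 heavy atoms (4 carbon, 2 nitrogen, 1 oxygen; one six-membered non-aromatic ring with 2 hetero atoms), on a carbonyl carbon.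

Two measured steps offer guidance. One is a 4.2-fold higher number from compound 1 to compound 2 (0.62 log units; beyond the scatter), on an aromatic carbon. The other is a 1.2-fold lower number from compound 2 to compound 3 (0.06 log units; within the scatter), on a saturated chain carbon bound to an aromatic carbon. Neither falls on the carbonyl carbon, but the second brought in the group that is now changed, and it stayed within the scatter despite replacing a much smaller group. For the measured compounds named here, no measured step isolates the new change, so the expectation remains uncertain. No step beyond the scatter is therefore expected in this assay, and the estimated step is a 1.1-fold higher number from compound 3 to compound 4 (0.04 log units; within the scatter). Compound 4 is estimated at 8 uM, with an expected range of 3 uM to 20 uM.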

Compound 4, concentration for half-maximal effect: 12 uM
Beside the measured number, compound 4's estimate is 1.5-fold (0.18 log units) below it; the measured number falls inside the stated range.
By their numbers in this assay, from the lowest: compound 1; then compounds 3, 2 and 4 (each within the scatter of the next).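

In this assay, replacing the ring on the carbonyl carbon with morpholin-4-yl, which takes away the hydrogen-bond donor of the leaving group, gives a 1.6-fold higher number from compound 3 to compound 4 (0.22 log units; within the scatter), so the two groups cannot be told apart at this place. The change of dimethylamino to ((morpholin-4-yl)carbonyl)amino on the saturated chain carbon gives a 1.4-fold higher number from compound 2 to compound 4 (0.15 log units; within the scatter), which extends this flat picture to compound 4, whereas a 6.0-fold higher number from compound 1 to compound 4 (0.78 log units; beyond the scatter) shows that compound 1 keeps the lower number. Nothing available explains these results.

The compounds shown leave open whether a piperazine ring or a simple amine on the carbonyl carbon would also stay within the scatter. Also open, on these data alone, is whether the group of compound 1, placed on the saturated chain carbon, would keep its lower number.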